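Compound 1 loses its ((4-fluorophenyl)sulfonyl)amino group

The source may hold more compounds than are shown below. What is called first, only, known or untested is meant among the compounds shown, and "the series" means these compounds.

In a functional assay on KB cells (Homo sapiens) for antiproliferative activity, read by sulforhodamine B assay, with a stated time of 48 h (a lower number here means a stronger inhibitor of growth, a higher number a weaker inhibitor of growth), compound 1 (`Nc1ccccc1NC(=O)c1ccc(CCc2ccccc2NS(=O)(=O)c2ccc(F)cc2)cc1`) gives 884 nM and compound 2 (`COc1ccc(S(=O)(=O)Nc2ccccc2CCc2ccc(C(=O)Nc3ccccc3N)cc2)cc1OC`) gives 888 nM. Among the measured compounds shown here, these are the only two numbers so far, and they lie within the scatter of each other, so neither compound ranks ahead. Compound 3 (`Nc1ccccc1NC(=O)c1ccc(CCc2ccccc2)cc1`) is a much larger edit of compound 1: hydrogen in place of ((4-fluorophenyl)sulfonyl)amino on an aromatic carbon. It carries hydrogen in place of ((4-fluorophenyl)sulfonyl)amino on an aromatic carbon, ortho to a large group, and the rest of the core stays the same. For the measured compounds named here, the only measured step, a 1.0-fold higher number from compound 1 to compound 2 (0.00 log units; within the scatter), exchanges 4-fluorophenyl for 3,4-dimethoxyphenyl on the sulfonyl sulfur and keeps the sulfonyl group itself. Going by the values given here, that swap moved the number no further than the scatter, but it says nothing direct about removing the whole group, and no measured compound lacks it. The expectation is therefore a cautious lean towards weaker growth inhibition in this assay, with wide uncertainty. The step expected is a 2.8-fold higher number from compound 1 to compound 3 (0.45 log units; beyond the scatter). For compound 3 the estimated value is 2500 nM, with an expected range of 700 nM to 9000 nM.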

Compound 3, concentration for 50% growth inhibition: > 10000 nM
Compound 3: only a limit was reported; the forecaster's own chance of this, stated with the estimate: 5%; middle value at least 4.0-fold (0.60 log units) away from the limit.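

The earlier swap on the sulfonyl sulfur, a 1.0-fold higher number from compound 1 to compound 2 (0.00 log units; within the scatter), kept the sulfonylamino link in place and so could not show whether this part of the molecule matters at all. Taking the whole ((4-fluorophenyl)sulfonyl)amino group off this aromatic carbon, ortho to a large group, and leaving only hydrogen gives an at least 11-fold higher number from compound 1 to compound 3 (1.05 log units; beyond the scatter) in this assay, so growth inhibition at the level of compound 1 depends on something in that group, a dependence the swap on the sulfur could not reveal. The value of compound 3 is a limit and not a number, so the step has a known minimum but no known full size: the limit of > 10000 nM in this assay, at which 1 of the 3 values shown sits.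

The compounds shown leave open which part of the group carries the effect: an amine on this carbon would keep only the nitrogen, while a methylsulfonylamino group would keep the sulfonyl but lose the aromatic ring. They also leave open how much the place itself counts, since the ((4-fluorophenyl)sulfonyl)amino group appears here on only this one aromatic carbon.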